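A few compounds are considered here, and "the series" means these few. Any claim that something is new, unique, unknown or untested is made for them only; others in the source may bear on it.

Compound 3 `COc1cc(-c2ccnc3cc(-c4ccc(N(C)C)cc4)nn23)cc(OC)c1OC` gives the lowest number of the three in a functional assay on MCF7 cells (Homo sapiens) for inhibition, read by CCK-8 assay, with a stated time of 48 h (a lower number here means a stronger inhibitor, a higher number a weaker inhibitor), at 44 nM; compound 1 `COc1cc(-c2ccnc3cc(-c4ccc(C)cc4)nn23)cc(OC)c1OC` sits within the scatter of it at 47 nM, while compound 2 `COc1cc(-c2ccnc3cc(-c4ccc(C(C)=O)cc4)nn23)cc(OC)c1OC` lies far away at 5230 nM. Compound 4 `CCOC(=O)c1ccc(-c2cc3nccc(-c4cc(OC)c(OC)c(OC)c4)n3n2)cc1` differs from compound 3 in one place: ethoxycarbonyl in place of dimethylamino on an aromatic carbon. The step that bears on it most is a 120-fold lower number from compound 2 to compound 3 (2.08 log units; beyond the scatter): acetyl, like the entering ethoxycarbonyl, holds a carbonyl. The step of a 110-fold higher number from compound 1 to compound 2 (2.05 log units; beyond the scatter) points the same way, whereas a 1.1-fold lower number from compound 1 to compound 3 (0.03 log units; within the scatter) shows methyl and dimethylamino giving like numbers. A large rise in the number in this assay is therefore expected for compound 4, a 68-fold higher number from compound 3 to compound 4 (1.83 log units; beyond the scatter). Compound 4 is estimated at 3000 nM, with a range of 600 nM to 15000 nM.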

Compound 4, half-maximal inhibitory concentration: > 10000 nM
Compound 4 ended at the assay's limit (the forecaster's own chance of this, stated with the estimate: 10%); middle value at least 3.3-fold (0.52 log units) from the limit.
By their numbers in this assay, from the lowest: compounds 3 and 1 (each within the scatter of the next); then compound 2. At a limit, above all of these: compound 4.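

With ethoxycarbonyl on this aromatic carbon, para to a large group, compound 4 stands at a limit of this assay and not at a number: the limit of > 10000 nM in this assay, at which 1 of the 4 values shown sits.
Both an at least 220-fold higher number from compound 3 to compound 4 (2.35 log units; beyond the scatter) and an at least 210-fold higher number from compound 1 to compound 4 (2.32 log units; beyond the scatter) show that a second group holding a carbonyl, after acetyl, gives a large rise over dimethylamino and methyl at this position. With an at least 1.9-fold higher number from compound 2 to compound 4 (0.28 log units; that floor lies within the scatter), ethoxy and methyl on the carbonyl carbon cannot be told apart.

As far as these compounds go, how a carboxylic acid or an amide would behave at this position remains open. So does whether a primary amine would match dimethylamino.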